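Swapping ethyl for pyridin-2-yl on a shared core

The source may hold more compounds than are shown below. What is called first, only, known or untested is meant among the compounds shown, and "the series" means these compounds.

Of the compounds shown here, two that share one core have been tested so far in a functional assay on NB1 cells (Homo sapiens) for cytotoxicity, read by MTT assay, with a stated time of 3 days; a lower number here means a stronger inhibitor, a higher number a weaker inhibitor. Compound 1 `N#Cc1c(Cl)nc(SCc2nc3ccccc3[nH]2)nc1-c1ccccc1` gives 2.87 nM, and compound 2 `CCNc1nc(SCc2nc3ccccc3[nH]2)nc(-c2ccccc2)c1C#N` gives 2.63 nM. Going by the values given here, compound 2 therefore stands level with the only other measured compound, within the usual scatter of repeat measurements. Compound 3 `N#Cc1c(Nc2ccccn2)nc(SCc2nc3ccccc3[nH]2)nc1-c1ccccc1` has not yet been measured. It keeps the core of compound 2 but carries pyridin-2-yl in place of ethyl on a nitrogen on an aromatic ring. Among the compounds with values here, only one measured step bears on this change: a 1.1-fold lower number from compound 1 to compound 2 (0.04 log units; within the scatter), with ethylamino in place of chloro on an aromatic carbon. That step lies within the scatter, so the number did not respond measurably to that exchange. Within the data shown here, no measured compound carries pyridin-2-yl, however, so this evidence is thin and gives no direction. The expected result is therefore no shift beyond the scatter, with an estimated step of a 1.1-fold higher number from compound 2 to compound 3 (0.06 log units; within the scatter). For compound 3 the estimated value is 3 nM, with an expected range from 0.9 nM to 10 nM.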

Compound 3, half-maximal inhibitory concentration: 3.9 nM
Beside the measured number, compound 3's estimate is 1.3-fold (0.11 log units) below it; low and high end bracket the measured number.
By their numbers in this assay, from the lowest: compounds 2, 1 and 3 (each within the scatter of the next).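

In this assay, putting pyridin-2-yl in place of ethyl on the nitrogen gives a 1.5-fold higher number from compound 2 to compound 3 (0.17 log units; within the scatter) and so stays within the scatter. This place on the shared core therefore carries a six-membered aromatic ring as well as a small chain without any measurable shift in the number. Comparing the (pyridin-2-yl)amino group directly with chloro on the aromatic carbon gives a 1.4-fold higher number from compound 1 to compound 3 (0.13 log units; within the scatter) and likewise stays within the scatter, so chloro, ethylamino and (pyridin-2-yl)amino all read alike here, and no measurement shown explains why the number stays so flat across these three compounds.

The three compounds leave open whether any group at this place can move the number beyond the scatter, for instance a plain amino group, a carboxylic acid, a longer alkyl chain or a phenyl ring in place of the pyridin-2-yl. They also say nothing about the rest of the shared core, since the nitrile and the phenyl group stay the same in all three compounds, and a change in either could behave quite differently from the changes seen so far.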